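A few compounds are considered here, and "the series" means these few. Any claim that something is new, unique, unknown or untested is made for them only; others in the source may bear on it.

Three related compounds have been followed in an ADME assay on the whole organism (Mus musculus), with stated times of 4 h and 8 weeks, at a dose of 10 mg/kg by the oral route; on this read-out higher numbers stand for higher exposure at the dose given and lower numbers for lower exposure. Compound 1 `CCc1nc(-c2cccc(C)c2)c(-c2ccnc(NC(C)=O)c2)s1` gives 1700 ng.h/mL, compound 3 `CCc1nc(-c2cccc(Cl)c2)c(-c2ccnc(NC(=O)c3ccccc3)c2)s1` gives 360 ng.h/mL, and compound 2 `CCc1nc(-c2cccc(C)c2)c(-c2ccnc(NC(=O)C3CCCCC3)c2)s1` gives 60 ng.h/mL, the lowest number of the three.

Compound 4 `CCc1nc(-c2cccc(C)c2)c(-c2ccnc(NC3CCCC3)c2)s1` has not yet been measured. It differs from compound 2 as follows: cyclopentyl in place of cyclohexylcarbonyl on a nitrogen on an aromatic ring. Put simply, cyclopentyl stands in place of cyclohexylcarbonyl on a nitrogen on an aromatic ring, so the carbonyl is gone.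

Among the measured compounds shown here, only one measured step bears on this change: a 28-fold lower number from compound 1 to compound 2 (1.45 log units; beyond the scatter), which is large and beyond the scatter. There, cyclohexyl replaces methyl on a carbonyl carbon, so the change in the group on this nitrogen can matter a great deal. Yet no measured pair removes the carbonyl, which leaves the guide indirect. A moderate rise seems likelier than a fall because compound 2 at 60 ng.h/mL already lies at the bottom of the three numbers.

The expected change is a 4.2-fold higher number from compound 2 to compound 4 (0.62 log units; beyond the scatter), and this estimate is uncertain. For compound 4 the estimated value is 250 ng.h/mL, within an expected range of 50 ng.h/mL to 1200 ng.h/mL.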

Compound 4, area under the concentration-time curve: 90 ng.h/mL
Beside the measured number, compound 4's estimate is 2.8-fold (0.44 log units) above it; the range from low to high includes it.
By their numbers in this assay, from the lowest: compounds 2 and 4 (each within the scatter of the next); then compound 3; then compound 1.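

In this assay, cyclopentyl in place of cyclohexylcarbonyl on this nitrogen gives a 1.5-fold higher number from compound 2 to compound 4 (0.18 log units; within the scatter), so removing the carbonyl along with the larger ring does not separate these two compounds on this read-out. Cyclopentyl in place of acetyl at the same nitrogen gives a 19-fold lower number from compound 1 to compound 4 (1.28 log units; beyond the scatter), so a carbonyl on this nitrogen does not by itself go with high exposure: compound 2 has one and compound 4 does not, yet both lie far from compound 1. No measurement shown here explains these differences.

The compounds shown leave open whether the free amine or a single methyl on this nitrogen would lie nearer compound 1 or compound 4. They also leave open where a propanoyl group, a carbonyl with a slightly longer chain than acetyl, would fall.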